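Swapping the anilino substituent: a chlorophenyl analogue awaits testing

A few compounds are considered here, and "the series" means these few. Any claim that something is new, unique, unknown or untested is made for them only; others in the source may bear on it.

Compound 1 `CC(C)c1ccc(-c2nc(SCc3cn(CC(=O)NC(=O)Nc4ccccn4)nn3)nc(Nc3ccc(Cl)cc3)c2C#N)cc1`: in a functional assay on MCF7 cells (Homo sapiens) for inhibition, read by MTT assay, with a stated time of 72 h (on this read-out lower numbers stand for stronger inhibition and higher numbers for weaker inhibition), compound 1 reaches only a limit of the assay, > 64000 nM.
Compound 2 `COc1cc(-c2nc(SCc3cn(CC(=O)NC(=O)Nc4ccccn4)nn3)nc(Nc3ccc(C(C)C)cc3)c2C#N)cc(OC)c1OC`: compound 2 gives 30900 nM.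
Compound 3 `COc1cc(-c2nc(SCc3cn(CC(=O)NC(=O)Nc4ccccn4)nn3)nc(Nc3cccc(C(F)(F)F)c3)c2C#N)cc(OC)c1OC`: compound 3 gives 8140 nM.

Compound 3 holds the lowest number of the two that are numbers; compound 2 is its nearest neighbour. Going by the values given here, the one measured step, a 3.8-fold lower number from compound 2 to compound 3 (0.58 log units; beyond the scatter), shows that exchanging the group on the aromatic nitrogen shifts the read-out modestly. Compound 4 `COc1cc(-c2nc(SCc3cn(CC(=O)NC(=O)Nc4ccccn4)nn3)nc(Nc3ccc(Cl)cc3)c2C#N)cc(OC)c1OC` makes a further exchange at that nitrogen: 4-chlorophenyl in place of 3-(trifluoromethyl)phenyl on a nitrogen on an aromatic ring. That step and compound 1, which sits at the limit (the limit of > 64000 nM in this assay, at which 1 of the 3 values shown sits), point towards a weaker result. The change from compound 3 to compound 4 is expected to be a 2.5-fold higher number from compound 3 to compound 4 (0.39 log units; beyond the scatter). Compound 4 is therefore estimated at 20000 nM, within a range from 6000 nM to 64000 nM.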

Compound 4, half-maximal inhibitory concentration: 45100 nM
For compound 4 the middle estimate is 2.3-fold (0.35 log units) below the measured one; the measured number falls inside the stated range.
By their numbers in this assay, from the lowest: compound 3; then compounds 2 and 4 (each within the scatter of the next). At a limit, above all of these: compound 1.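

Compound 3 now stands apart at this nitrogen: 4-chlorophenyl in place of 3-(trifluoromethyl)phenyl gives a 5.5-fold higher number from compound 3 to compound 4 (0.74 log units; beyond the scatter), so both other groups seen there with this core give higher numbers. Chloro in place of isopropyl on an aromatic carbon gives a 1.5-fold higher number from compound 2 to compound 4 (0.16 log units; within the scatter), so those two groups cannot be told apart here. With compound 1 at a limit of the assay, 3,4,5-trimethoxyphenyl in place of 4-isopropylphenyl on an aromatic carbon gives only an at least 1.4-fold lower number from compound 1 to compound 4 (0.15 log units; that floor lies within the scatter).

Going by these compounds alone, open is whether the lower number of compound 3 follows the trifluoromethyl group itself or its place on the ring, as no pair here separates the two. Also open, on these data alone, is how an amine or a carboxylic acid on that ring would read out.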